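Aryl sulfonate series: chloro in place of nitro

This account rests on a few compounds, and the source may have more. Where it says the series, first, only, none or still open, it means among the compounds named here.

Values in a functional assay on HL-60 cells (Homo sapiens) for inhibition, read by CCK-8 assay, with a stated time of 48 h; on this read-out higher numbers stand for weaker inhibition and lower numbers for stronger inhibition:
- compound 1 `COc1ccc(Cc2nnc(NC(=O)/C(C#N)=C/c3ccccc3OS(=O)(=O)c3ccc(OC)cc3)s2)cc1`: 3120 nM
- compound 2 `COc1ccc(Cc2nnc(NC(=O)/C(C#N)=C/c3ccccc3OS(=O)(=O)c3ccc([N+](=O)[O-])cc3)s2)cc1`: 10900 nM

Going by the values given here, of the two numbers so far, the higher belongs to compound 2 at 10900 nM. Compound 3 `COc1ccc(Cc2nnc(NC(=O)/C(C#N)=C/c3ccccc3OS(=O)(=O)c3ccc(Cl)cc3)s2)cc1` carries chloro in place of nitro on an aromatic carbon, para to a large group: chloro in place of nitro on an aromatic carbon. Among the compounds with values here, the only measured step at this place, a 3.5-fold higher number from compound 1 to compound 2 (0.54 log units; beyond the scatter), is nitro in place of methoxy. Within the data shown here, on that single step, a modest move toward a lower number is expected in this assay, possibly no larger than that step. The expected change is a 2.0-fold lower number from compound 2 to compound 3 (0.30 log units; within the scatter). For compound 3 the estimated value is 5500 nM, with an expected range of 2200 nM to 13000 nM.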

Compound 3, half-maximal inhibitory concentration: 11400 nM
The estimate for compound 3 lay 2.1-fold (0.32 log units) below the measured number; low and high end bracket the measured number.
By their numbers in this assay, from the lowest: compound 1; then compounds 2 and 3 (each within the scatter of the next).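

In this assay the change to 4-chlorophenyl gives a 1.0-fold higher number from compound 2 to compound 3 (0.02 log units; within the scatter) and leaves chloro and nitro unseparated at this carbon, para to a large group. Chloro in place of methoxy gives a 3.7-fold higher number from compound 1 to compound 3 (0.56 log units; beyond the scatter) and so, of these three groups, only methoxy in compound 1 stands apart, with the lowest number. No measured evidence accounts for this grouping.

On these data alone, whether the separation belongs to methoxy alone stays open. A hydroxyl, a methyl or a dimethylamino group at this carbon would test it, as would an unsubstituted phenyl.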